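Cytotoxicity notes on the shared core: nitrophenyl step

The source may hold more compounds than are shown below. What is called first, only, known or untested is meant among the compounds shown, and "the series" means these compounds.

Measured in an ADME assay on HEK293 cells (Homo sapiens) for cytotoxicity, read by CellTiter-Glo and resazurin assay, with a stated time of 72 h; on this read-out lower numbers stand for an effect already at smaller amounts and higher numbers for an effect only at larger amounts of compound:
- compound 1 `CC(C)N(Cc1cccc(OCCCCCC(=O)O)c1)C(=O)c1ccc(-c2cccc([N+](=O)[O-])c2)cc1` gives only a limit, > 26000 nM
- compound 2 `CCOC(=O)CCCCCOc1cccc(CN(C(=O)c2ccc(-c3cccc(OC)c3)cc2)C(C)C)c1` gives only a limit, > 21000 nM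
- compound 3 `CCOC(=O)CCCCCOc1cccc(CN(C(=O)c2ccc(-c3ccc4c(c3)OCCO4)cc2)C(C)C)c1` gives only a limit, > 24400 nM

Compound 3 stands at a limit in this assay, not at a number. The same holds for every value shown: one value sits at the limit of > 21000 nM in this assay, at which 1 of the 3 values shown sits, one at the limit of > 24400 nM in this assay, at which 1 of the 3 values shown sits, and one at the limit of > 26000 nM in this assay, at which 1 of the 3 values shown sits.

The change from compound 3 to compound 4 `CCOC(=O)CCCCCOc1cccc(CN(C(=O)c2ccc(-c3cccc([N+](=O)[O-])c3)cc2)C(C)C)c1` is 3-nitrophenyl in place of 2,3-dihydro-1,4-benzodioxin-6-yl on an aromatic carbon.

Among the compounds with values here, the only measured step that touches the same position, a step that the two limits leave unreadable from compound 2 to compound 3, is unreadable. Compound 1 carries the same 3-nitrophenyl group beside a different chain end, and its value shows only a limit. No readable step on the shared core is therefore available, and no effect beyond the scatter is expected from this change in this assay.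

Compound 4 is estimated at 25000 nM, with a range from 15000 nM to 50000 nM, and is expected to return a limit again, which is what the step that the limit leaves unreadable from compound 3 to compound 4 from compound 3 means.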

Compound 4, half-maximal effective concentration: > 26000 nM
Compound 4 gave a limit, no number; the forecaster's own chance of this, stated with the estimate: 85%; middle value at least 1.0-fold (0.01 log units) from the limit.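

Compound 4, like compound 1, compound 2 and compound 3, gives only a limit in this assay; none of its steps to those three compounds can be read. The compounds shown leave open at what concentration any of them reaches a half-maximal effect, and whether the group on the aromatic carbon or the chain end alters it.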